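Extending the methoxy of compound 2 to benzyloxy

The compounds below may be only part of what the source reports. "The series", "measured", "known", "first", "only" and "open" are said of these compounds alone.

Of the compounds shown here, two have been measured in an assay on isolated protein for inhibition of Amine oxidase [flavin-containing] B (Homo sapiens), read by fluorescence and Amplex Red, with stated times of 15 min and 20 min; on this read-out higher numbers stand for weaker inhibition and lower numbers for stronger inhibition. Compound 1 `O=C(NCCC1CCN(Cc2ccccc2)CC1)c1coc2ccccc2c1=O` gives 35300 nM in this assay, and compound 2 `COc1ccc2occ(C(=O)NCCC3CCN(Cc4ccccc4)CC3)c(=O)c2c1` gives 11200 nM. Among the compounds with values here, the single step between them, a 3.2-fold lower number from compound 1 to compound 2 (0.50 log units; beyond the scatter), is the only one recorded. Compound 2 therefore holds the lowest of the two numbers, with compound 1 as its nearest neighbour.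

Compound 3 `O=C(NCCC1CCN(Cc2ccccc2)CC1)c1coc2ccc(OCc3ccccc3)cc2c1=O` has not yet been measured. It differs from compound 2 by phenyl in place of hydrogen on a saturated chain carbon bound to an oxygen on an aromatic ring, so that the methoxy of compound 2 becomes a benzyloxy. Within the data shown here, no measured step adds a phenyl at this place; the step from compound 1 to compound 2 shows only that filling this position with methoxy lowered the number. The account therefore expects a modest further lowering for compound 3 in this assay, a 2.8-fold lower number from compound 2 to compound 3 (0.45 log units; beyond the scatter), with wide uncertainty. The estimated value for compound 3 is 4000 nM, expected to lie between 800 nM and 20000 nM.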

Compound 3, half-maximal inhibitory concentration: 272 nM
Compound 3: middle estimate off by 15-fold (1.17 log units), on the high side, and the stated range ends above it.
By their numbers in this assay, from the lowest: compound 3; then compound 2; then compound 1.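

In this assay the phenyl added to the methoxy carbon gives a 41-fold lower number from compound 2 to compound 3 (1.61 log units; beyond the scatter), a far larger change than the methoxy itself brought, a 3.2-fold lower number from compound 1 to compound 2 (0.50 log units; beyond the scatter). The place on the aromatic carbon therefore has much more to give than compound 2 suggested: benzyloxy in place of hydrogen gives a 130-fold lower number from compound 1 to compound 3 (2.11 log units; beyond the scatter), and most of that lowering arrives only with the phenyl. Nothing available explains why the added phenyl has so large an effect.

The compounds shown do not tell whether the aromatic ring itself is needed, or whether a longer chain such as butoxy or a cyclohexylmethoxy group would serve as well. They also leave open whether a chlorine or a nitrile on the added phenyl would lower the number further.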